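Aryl variation on a pyrrolopyridine ether amide series

The source may report more compounds than this note shows. Statements on the series, on what has been measured and on what is new or still open speak of the compounds shown alone.

Measured compounds:
compound 1 `Cc1ccc(-c2ccnc(C(=O)Nc3ccc(Oc4ccnc5[nH]ccc45)cc3)n2)cc1`: 2380 nM
compound 2 `O=C(Nc1ccc(Oc2ccnc3[nH]ccc23)cc1)c1nccc(-c2cccc(Cl)c2)n1`: 4120 nM

In a functional assay on A549 cells (Homo sapiens) for cytotoxicity, read by MTT assay, with a stated time of 72 h (a lower number here means a stronger inhibitor, a higher number a weaker inhibitor), compound 2 gives 4120 nM, the highest of the two numbers at hand; its nearest neighbour is compound 1, which gives 2380 nM, a gap that lies within the scatter. Compound 3 `COc1ccc(-c2ccnc(C(=O)Nc3ccc(Oc4ccnc5[nH]ccc45)cc3)n2)cc1` has not been measured. It differs from compound 2 by 4-methoxyphenyl in place of 3-chlorophenyl on an aromatic carbon. Among the measured compounds shown here, the only measured step that bears on this change is a 1.7-fold higher number from compound 1 to compound 2 (0.24 log units; within the scatter), which exchanged one substituted phenyl for another at the same aromatic carbon and stayed within the scatter. A further exchange of this kind is therefore expected to give no step beyond the scatter in this assay either, with compound 3 expected to land near compound 1 and compound 2. Compound 3 is thus expected to give 2900 nM, between 1200 nM and 7000 nM, an expected change of a 1.4-fold lower number from compound 2 to compound 3 (0.15 log units; within the scatter).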

Compound 3, half-maximal inhibitory concentration: 13300 nM
The estimate for compound 3 lay 4.6-fold (0.66 log units) below the measured number; the whole stated range lies below it.
By their numbers in this assay, from the lowest: compounds 1 and 2 (each within the scatter of the next); then compound 3.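

The earlier exchange at this aromatic carbon had stayed within the scatter, but in this assay the position proves sensitive to which substituted phenyl it carries: 4-methoxyphenyl in place of 3-chlorophenyl gives a 3.2-fold higher number from compound 2 to compound 3 (0.51 log units; beyond the scatter) and so moves the number clearly upward. The cleaner comparison is methoxy in place of methyl on the phenyl, which gives a 5.6-fold higher number from compound 1 to compound 3 (0.75 log units; beyond the scatter) and shows that this one small exchange is enough to raise the number beyond the scatter. No measurement at hand accounts for this rise.

The compounds shown leave open whether the rise belongs to the methoxy group itself or to where it stands on the phenyl, which 3-methoxyphenyl would separate. They also leave open how an unsubstituted phenyl, a hydroxy group, an ethoxy group or an amine on the phenyl would compare.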